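Second methoxy on the aryl amine of compound 3

The compounds below may be only part of what the source reports. "The series", "measured", "known", "first", "only" and "open" are said of these compounds alone.

Compound 3 `COc1ccc(Nc2ncnc3cc(OC)c(OCCCCC(=O)Nc4ccc(S(N)(=O)=O)cc4)cc23)cc1` gives 14700 nM in a functional assay on A-431 cells (Homo sapiens) for antiproliferative activity, read by MTT assay, with a stated time of 72 h; a lower number here means a stronger inhibitor, a higher number a weaker inhibitor. Among the three measured compounds it holds the second highest number. Compound 2 `C#Cc1cccc(Nc2ncnc3cc(OC)c(OCCCCC(=O)Nc4ccc(S(N)(=O)=O)cc4)cc23)c1` gives 17700 nM, and a 1.2-fold lower number from compound 2 to compound 3 (0.08 log units; within the scatter). Compound 1 `COc1cc2ncnc(Nc3ccc(Cl)c(C(F)(F)F)c3)c2cc1OCCCCC(=O)Nc1ccc(S(N)(=O)=O)cc1` gives 3910 nM; here a 3.8-fold higher number from compound 1 to compound 3 (0.58 log units; beyond the scatter), and likewise a 4.5-fold higher number from compound 1 to compound 2 (0.66 log units; beyond the scatter).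

Compound 4 `COc1ccc(Nc2ncnc3cc(OC)c(OCCCCC(=O)Nc4ccc(S(N)(=O)=O)cc4)cc23)cc1OC` differs from compound 3 by methoxy in place of hydrogen on an aromatic carbon. Among the compounds with values here, no measured step makes this exact change; each of the three measured steps exchanges the whole aryl group on the same nitrogen. Even those larger exchanges give only modest steps, and the exchange between the two aryl groups nearest to the new one in the numbers, compound 2 to compound 3, lies within the scatter. A step beyond the scatter is therefore not expected for compound 4 in either direction, and its step is estimated at a 1.1-fold lower number from compound 3 to compound 4 (0.02 log units; within the scatter). Compound 4 is expected to give 14000 nM. The expected range for compound 4 runs from 5000 nM to 40000 nM.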

Compound 4, half-maximal inhibitory concentration: 35400 nM
Estimate against measurement, compound 4: 2.5-fold (0.40 log units) below; the measured number falls inside the stated range.
By their numbers in this assay, from the lowest: compound 1; then compounds 3, 2 and 4 (each within the scatter of the next, the first and the last beyond it).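

In this assay, within the data shown here, methoxy in place of hydrogen on an aromatic carbon, ortho to a methoxy group, gives the first reading of a single change on this aryl group, and the change is not neutral (a 2.4-fold higher number from compound 3 to compound 4 (0.38 log units; beyond the scatter)), whereas every earlier step exchanged the whole aryl group. The 3,4-dimethoxyphenyl group gives no separation from 3-ethynylphenyl (a 2.0-fold higher number from compound 2 to compound 4 (0.30 log units; within the scatter)), but the gap to 4-chloro-3-(trifluoromethyl)phenyl widens to the largest in the set (a 9.1-fold higher number from compound 1 to compound 4 (0.96 log units; beyond the scatter)). Nothing available explains the effect of the added methoxy.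

As far as these compounds go, whether a hydroxy group, a fluorine or an amine on that same aromatic carbon would behave as methoxy does stays open. So does whether the step carries over to a longer or shorter chain on the amide side.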